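Fluoro in place of hydrogen on the phenyl of compound 3

The source may report more compounds than this note shows. Statements on the series, on what has been measured and on what is new or still open speak of the compounds shown alone.

Compound 1 `COc1cc(N(C)C(=O)N(C)c2ccc([N+](=O)[O-])cc2)cc(OC)c1OC` — in a functional assay on Daoy cells (Homo sapiens) for cytotoxicity, read by MTT assay, with a stated time of 72 h (a lower number here means a stronger inhibitor, a higher number a weaker inhibitor), compound 1 gives >= 125000 nM, a limit of the assay.
Compound 2 `COc1cc(N(C)C(=O)N(C)c2cccc([N+](=O)[O-])c2)cc(OC)c1OC` — in this assay compound 2 gives >= 125000 nM, a limit of the assay.
Compound 3 `COc1cc(N(C)C(=O)N(C)c2ccccc2)cc(OC)c1OC` — in this assay compound 3 gives "not determined" (no result reported), so no result is reported for it.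

All three share one core, a urea carrying two methylated nitrogens, a trimethoxyphenyl on one side and an aryl group on the other. Going by the values given here, the only change among the measured pair is 3-nitrophenyl in place of 4-nitrophenyl on an amide-type nitrogen, and the step that the two limits leave unreadable from compound 1 to compound 2 cannot be read, since both values sit at the limit of >= 125000 nM in this assay, at which 2 of the 3 values shown sit. Compound 3, with a plain phenyl, therefore stands nowhere on the numbers: no value is known for it, and the two neighbouring values are limits rather than numbers.

Compound 4 `COc1cc(N(C)C(=O)N(C)c2ccc(F)cc2)cc(OC)c1OC` differs from compound 3 by fluoro in place of hydrogen on an aromatic carbon. Among the compounds with values here, no measured step bears on this change, and the one step that is available is itself unreadable. With both measured compounds at the limit of this assay, the most that can be said is that nothing in the data points to a stronger inhibitor. Compound 4 is accordingly expected to come out near 125000 nM, with a range from 30000 nM to 500000 nM, and the result is quite likely to be another limit.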

Compound 4, half-maximal inhibitory concentration: >= 125000 nM
Compound 4: only a limit was reported (the forecaster's own chance of this, stated with the estimate: 65%); the middle value sits exactly at the limit.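

Compound 1, compound 2 and compound 4 each give only a limit of the assay, not a number, so no step among these three can be read: the limit of >= 125000 nM in this assay, at which 3 of the 4 values shown sit.

The compounds shown leave open whether any aryl group on the shared core gives an actual number in this assay, and where compound 3, with its plain phenyl, stands.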